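This account rests on a few compounds, and the source may have more. Where it says the series, first, only, none or still open, it means among the compounds named here.

In a physicochemical assay for lipophilicity, at pH 7.4 (on this read-out higher numbers stand for higher lipophilicity and lower numbers for lower lipophilicity), compound 1 `Cc1nc2ccccc2c(OCc2ccccc2)c1Br` gives 2.52 and compound 2 `COc1ccc2[nH]c(C)c(Br)c(=O)c2c1` gives 1.62 as the lower of the two numbers, a gap beyond the scatter. Compound 3 `Cc1[nH]c2ccc(F)cc2c(=O)c1Br` differs from compound 2 in one place: fluoro in place of methoxy on an aromatic carbon with fluoro in place of methoxy on an aromatic carbon. For the measured compounds named here, no measured step of this kind exists, so the expectation rests on the structural change alone. The step expected in this assay is small and upward, within the scatter: a number 0.13 log units higher from compound 2 to compound 3 (within the scatter) as the estimated shift. Compound 3 is estimated at 1.75 with an expected range from 1.35 to 2.15 on this read-out.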

Compound 3, distribution coefficient: 1.61
Compound 3: the middle estimate sits 0.14 log units above what was measured; the range from low to high includes it.
By their numbers in this assay, from the lowest: compounds 3 and 2 (each within the scatter of the next); then compound 1.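

In this assay, fluoro in place of methoxy on this aromatic carbon gives a number 0.01 log units lower from compound 2 to compound 3 (within the scatter), the first step read at this position. The read-out therefore does not separate the two groups here, even though a group counted with a hydrogen-bond acceptor gives way to one counted without any. Nothing at hand accounts for this result.

On these data alone, whether an amine or a carboxylic acid on this aromatic carbon would stay as close to methoxy remains open. So does whether fluoro and methoxy stay this close on other carbons of the shared core.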